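A few compounds are considered here, and "the series" means these few. Any claim that something is new, unique, unknown or untested is made for them only; others in the source may bear on it.

Compound 1 `O=c1cc(CNCc2ccccc2[N+](=O)[O-])oc2ccc(O)c(O)c12` in an ADME assay on Huh-7 cells (Homo sapiens) for cytotoxicity (on this read-out higher numbers stand for lower toxicity in this test and lower numbers for higher toxicity in this test), gives 41300 nM.
Compound 2 `O=c1cc(CNCc2cccc(Cl)c2)oc2ccc(O)c(O)c12` in this assay gives only a limit, > 100000 nM.
Compound 3 `O=c1cc(CNCc2cccc([N+](=O)[O-])c2)oc2ccc(O)c(O)c12` in this assay likewise gives only a limit, > 100000 nM.

Compound 4 `O=c1cc(CNCc2ccc(O)cc2)oc2ccc(O)c(O)c12` has not been measured in this assay. Compound 2 stands at the limit of > 100000 nM in this assay, at which 2 of the 3 values shown sit, so for it no number is known, only that its half-maximal cytotoxic concentration lies beyond the reach of the test. The change from compound 2 to compound 4 is 4-hydroxyphenyl in place of 3-chlorophenyl on a saturated chain carbon bound to an amine nitrogen. Among the compounds with values here, the only measured step that touches compound 2 is a step that the two limits leave unreadable from compound 2 to compound 3, and it cannot be read because both of its ends are limits; no other measured pair exchanges a 3-chlorophenyl for a 4-hydroxyphenyl. There is therefore no basis to expect a step beyond the scatter in either direction, and compound 4 is expected to sit near the limit, as compound 2 does, with an at least 1.1-fold lower number from compound 2 to compound 4 (0.04 log units; that floor lies within the scatter). Compound 4 is accordingly estimated at 90000 nM, within a range from 35000 nM to 250000 nM, with a fair chance that this assay again reports only a limit.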

Compound 4, half-maximal cytotoxic concentration: 62700 nM
The estimate for compound 4 lay 1.4-fold (0.16 log units) above the measured number; the measured number falls inside the stated range.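

In this assay, the exchange at this place yields a step with a readable floor, an at least 1.5-fold lower number from compound 2 to compound 4 (0.20 log units; that floor lies within the scatter), whereas the earlier step to compound 3 cannot be read, with a limit at both of its ends. Going by these compounds, that floor alone does not show a change beyond the scatter, and the true size of the step stays unknown because compound 2 sits at a limit: the limit of > 100000 nM in this assay, at which 2 of the 4 values shown sit. Even so, compound 4 shows that a ring on this saturated chain carbon can give a measured number rather than a limit when it carries a hydroxyl group.

The compounds shown leave open whether the hydroxyl group or its place on the ring matters more, as they include neither 3-hydroxyphenyl nor 4-chlorophenyl. They also leave open how a ring bearing a methoxy group, an amine or a carboxylic acid would behave here.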